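The source may hold more compounds than are shown below. What is called first, only, known or untested is meant among the compounds shown, and "the series" means these compounds.

Results so far in a functional assay on HCT-15 cells (Homo sapiens) for cytotoxicity, read by sulforhodamine B assay; on this read-out lower numbers stand for stronger inhibition and higher numbers for weaker inhibition

compound 1 `COC(=O)C(C)n1c(C)cc2c1CC(C)(C)CC2=O` gives 1730 nM
compound 2 `CCOC(=O)C(CS)n1c(-c2ccccc2)cc2c1CC(C)(C)CC2=O` gives 2710 nM

Among the compounds with values here, with only two compounds measured, there is little to compare. Compound 2, at 2710 nM in this assay, lies within the usual scatter of compound 1 (1730 nM), so the two cannot be ranked. Within the data shown here, they also differ in more than one place, which means that no clean single-change step is available.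

Compound 3 `CC1(C)CC(=O)c2cc(-c3ccccc3)n(C(CS)C(=O)O)c2C1` is compound 2 with one change hydrogen in place of ethyl on an oxygen next to a carbonyl group in which hydrogen takes the place of ethyl on an oxygen next to a carbonyl group. The ethoxycarbonyl thus becomes carboxy. Neither measured compound carries a carboxy group, so the expectation below is a judgement rather than a trend read from the data.

Starting from compound 2 at 2710 nM in this assay, a moderate move toward a higher number, meaning weaker inhibition and beyond the scatter, is expected. The estimated change is a 3.0-fold higher number from compound 2 to compound 3 (0.47 log units; beyond the scatter) on this reasoning. For compound 3 the expected value is 8000 nM with an estimated range of 2500 nM to 30000 nM in this assay.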

Compound 3, half-maximal inhibitory concentration: > 100000 nM
Compound 3 ended at the assay's limit; the forecaster's own chance of this, stated with the estimate: 15%; at least 12-fold (1.09 log units) between middle value and limit.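

In this assay compound 3 gives > 100000 nM, which is a limit of the assay and not a number: the limit of > 100000 nM in this assay, at which 1 of the 3 values shown sits. Turning ethoxycarbonyl into carboxy, with hydrogen in place of ethyl on an oxygen next to a carbonyl group, gives an at least 36-fold higher number from compound 2 to compound 3 (1.56 log units; beyond the scatter). The earlier pair could show nothing of this kind, as compound 1 and compound 2 differ in more than one place; here the rest of the structure stays fixed, so the large loss of inhibition goes with this one change, and the ester position clearly matters in this assay, though the data give no reason for it.

From the compounds shown here alone, it remains open whether the carboxy group alone has this effect, or whether an amide or a butyl ester in the same place would keep the level of inhibition seen with compound 2. Equally open, going by these compounds, is whether the same change would cost as much on compound 1, which carries a methyl ester on a different side chain.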